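The compounds below may be only part of what the source reports. "The series", "measured", "known", "first", "only" and "open" are said of these compounds alone.

Among the measured compounds shown here, only two compounds have been tested so far in a functional assay on KYSE-70 cells for antiproliferative activity against KYSE-70 cell line (Homo sapiens), read by MTT assay, with a stated time of 72 h; on this read-out higher numbers stand for weaker inhibition and lower numbers for stronger inhibition. Compound 1 `COc1cccc(NC(=O)c2cc(=O)[nH]c3cc(Br)ccc23)c1` gives > 20000 nM, which is a limit of the assay and not a number. For the measured compounds named here, compound 2 `O=C(Nc1cccc(F)c1)c1cc(=O)[nH]c2cc(-c3cccc(F)c3)ccc12` gives 12000 nM, the only true number available, so there is no other measured value to rank it against. Compound 3 `O=C(Nc1cccc(F)c1)c1cc(=O)[nH]c2cc(-c3cccnc3F)ccc12` keeps the rest of compound 2 but carries 2-fluoropyridin-3-yl in place of 3-fluorophenyl on an aromatic carbon. Going by the values given here, no measured pair shows what such an exchange does in this assay, so the expectation is no shift beyond the usual scatter. The expected move, a 1.2-fold higher number from compound 2 to compound 3 (0.07 log units; within the scatter), is therefore small. For compound 3 the estimated half-maximal inhibitory concentration is 14000 nM, within an expected range of 6000 nM to 20000 nM.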

Compound 3, half-maximal inhibitory concentration: > 20000 nM
Compound 3: a limit, no number; the forecaster's own chance of this, stated with the estimate: 30%; middle value at least 1.4-fold (0.15 log units) away from the limit.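

In this assay, among the compounds shown here, this is the first step that isolates the group on this aromatic carbon: 2-fluoropyridin-3-yl in place of 3-fluorophenyl gives an at least 1.6-fold higher number from compound 2 to compound 3 (0.22 log units; that floor lies within the scatter). The exchange brings no stronger inhibition than compound 2 shows, so adding a nitrogen to this ring offers no gain here. How large the step really is stays unknown, and it may or may not exceed the scatter, because the value of compound 3 is a limit and not a number: the limit of > 20000 nM in this assay, at which 2 of the 3 values shown sit.

The compounds shown leave open whether a simple amine or a carboxylic acid on this aromatic carbon would lower the number. They also leave open what the 3-fluorophenyl group contributes, as compound 1 and compound 2 differ in more than one place.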